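Removing the pyridinylmethyl ether from a 5-lipoxygenase inhibitor

The source may report more compounds than this note shows. Statements on the series, on what has been measured and on what is new or still open speak of the compounds shown alone.

The series shares a core carrying a pentenoic acid arm, a trifluoromethylbenzyl ether and a second aryloxy position that is varied. Compound 1 `CCCC/C(=C\c1cc(OCc2ccc(CCCC)cc2)ccc1OCc1ccc(C(F)(F)F)cc1)C(=O)O` bears a butylbenzyl group at that position, and in an assay on isolated protein for inhibition of Polyunsaturated fatty acid 5-lipoxygenase (Homo sapiens), read by HPLC, with a stated time of 15 min (a lower number here means a stronger inhibitor, a higher number a weaker inhibitor), compound 1 is reported as "not active" (no number reported), without a number. Compound 2 `CCCC/C(=C\c1cc(OCc2cccnc2)ccc1OCc1ccc(C(F)(F)F)cc1)C(=O)O` carries a (pyridin-3-yl)methyl group instead, and in this assay compound 2 gives 2300 nM, the only numerical result in the set. Among the compounds with values here, compound 2 therefore stands as the sole reference point; no step between two measured compounds can be drawn from these data.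

Compound 3 `CCCC/C(=C\c1cc(O)ccc1OCc1ccc(C(F)(F)F)cc1)C(=O)O` differs from compound 2 by hydrogen in place of (pyridin-3-yl)methyl on an oxygen on an aromatic ring. Since the only other variation at this oxygen, in compound 1, gave no measurable activity, the data offer no guide to the size of this step in either direction. The expectation for compound 3 is a weakening beyond the usual scatter, expressed as a 2.6-fold higher number from compound 2 to compound 3 (0.42 log units; beyond the scatter). On that basis compound 3 is estimated at 6000 nM in this assay, within a range from 1500 nM to 25000 nM.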

Compound 3, half-maximal inhibitory concentration: "not active" (no number reported)
The entry for compound 3 holds no number, and the estimate cannot be compared.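

In this assay, within the data shown here, compound 3 is reported without a number ("not active" (no number reported)), so no step from compound 2 to compound 3 can be read, and compound 2 keeps the only figure (2300 nM). The compounds shown leave open how compound 1 and compound 3 compare numerically with compound 2. No measurement shown here offers an explanation for this result.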